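Fluoro for methoxy on a weakly cytotoxic indole thiazole amide

The compounds below may be only part of what the source reports. "The series", "measured", "known", "first", "only" and "open" are said of these compounds alone.

Two compounds have been measured in a functional assay on PC-3 cells (Homo sapiens) for cytotoxicity, read by MTT assay, with a stated time of 48 h, in the absence of a further agent; on this read-out higher numbers stand for weaker inhibition and lower numbers for stronger inhibition:
compound 1, `COc1ccc2[nH]cc(-c3nc(C(=O)Nc4cc(OC)c(OC)c(OC)c4)cs3)c2c1`, gives 94300 nM.
compound 2, `COc1cc(NC(=O)c2csc(-c3cn(Cc4ccc(Cl)cc4)c4ccccc34)n2)cc(OC)c1OC`, gives only a limit of the assay, > 100000 nM.

Among the measured compounds shown here, compound 1 thus holds the only real number in this assay, and it sits at the weak end of the read-out. Compound 2 is recorded only at the limit of > 100000 nM in this assay, at which 1 of the 2 values shown sits, which is a limit and not a number.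

Compound 3, `COc1cc(NC(=O)c2csc(-c3c[nH]c4ccc(F)cc34)n2)cc(OC)c1OC`, differs from compound 1 by fluoro in place of methoxy on an aromatic carbon. For the measured compounds named here, no pair of measured compounds that differ in one place is available to set the size of such a step, so the expectation rests on compound 1 alone. In this assay the step from compound 1 to compound 3 is expected to stay within the usual scatter, with no preferred direction. Compound 3 is therefore expected to give about 90000 nM, with a range from 30000 nM to 300000 nM. Against compound 1, this estimate means an expected 1.0-fold lower number from compound 1 to compound 3 (0.02 log units; within the scatter).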

Compound 3, half-maximal inhibitory concentration: 89000 nM
Beside the measured number, compound 3's estimate is 1.0-fold (0.00 log units) above it; measured number inside the range.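

In this assay the step of a 1.1-fold lower number from compound 1 to compound 3 (0.03 log units; within the scatter) shows that fluoro can stand in place of methoxy on this aromatic carbon, on the six-membered aromatic ring of carbon only, with the result staying within the scatter. Methoxy leaves with its hydrogen-bond acceptor, and compound 3 still stands with compound 1 at the weak end of the read-out, which gives this position its first readable step. Nothing measured here gives a reason for this result.

From the compounds shown here alone, whether another group on this carbon, such as an amine or a carboxylic acid, would give a clearly different number stays open. Among the compounds shown here, compound 2 is held only at a limit of the assay and not at a number, so no step to it can be read: the limit of > 100000 nM in this assay, at which 1 of the 3 values shown sits.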